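Bromo substitution on the hydroxyphenyl hydrazone series

This account rests on a few compounds, and the source may have more. Where it says the series, first, only, none or still open, it means among the compounds named here.

Measured so far:
compound 1, `C/C(=N\NC(=O)c1cccc(S(=O)(=O)N2CCOCC2)c1)c1ccccc1O`: 1220 nM
compound 2, `C/C(=N\NC(=O)c1cccc(S(=O)(=O)N2CCOCC2)c1)c1cc(Br)ccc1O`: 24700 nM
compound 3, `O=C(N/N=C/c1cc(Br)ccc1O)c1cccc(S(=O)(=O)N2CCOCC2)c1`: 29700 nM

All three were run in a functional assay on EC9706 cells (Homo sapiens) for antiproliferative activity, read by MTT assay, with a stated time of 72 h; on this read-out higher numbers stand for weaker inhibition and lower numbers for stronger inhibition. Compound 2 differs from compound 1 by bromo in place of hydrogen on an aromatic carbon, and this gives a 20-fold higher number from compound 1 to compound 2 (1.31 log units; beyond the scatter). Compound 3 sits within the scatter of compound 2; how the core of compound 3 differs from the core of compound 1 is not broken down here.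

Compound 4, `O=C(N/N=C/c1cc(Br)cc(Br)c1O)c1cccc(S(=O)(=O)N2CCOCC2)c1`, is not yet measured. It differs from compound 3 by bromo in place of hydrogen on an aromatic carbon. This is the same kind of change as that from compound 1 to compound 2, but the place is not the same: in compound 2 the bromo enters para to a hydroxy group and meta to a large group, whereas in compound 4 it enters ortho to a hydroxy group, meta to a bromo group and meta to a large group.

Because the step of a 20-fold higher number from compound 1 to compound 2 (1.31 log units; beyond the scatter) was large, a further weakening is expected, though compound 3 already gives a high number, so the expected step is a 1.5-fold higher number from compound 3 to compound 4 (0.18 log units; within the scatter). Compound 4 is estimated at 45000 nM, expected between 14000 nM and 130000 nM.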

Compound 4, half-maximal inhibitory concentration: 2440 nM
Compound 4: the middle estimate sits 18-fold (1.27 log units) above what was measured; the whole stated range lies above it.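

In this assay, adding a bromo in place of hydrogen on an aromatic carbon gives a 12-fold lower number from compound 3 to compound 4 (1.09 log units; beyond the scatter). Set beside the earlier step, the same kind of change runs in opposite directions on the two cores: the same change on two cores in this assay, a 20-fold higher number (1.31 log units; beyond the scatter) from compound 1 to compound 2 and a 12-fold lower number (1.09 log units; beyond the scatter) from compound 3 to compound 4, 250-fold (2.39 log units) apart, beyond the scatter of two such steps

The effect of this change therefore cannot be carried from one core to another in this series as a fixed increment, but the two steps differ both in the core and in the place where the bromo enters, and this pair does not separate those two differences.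

Left open is whether the 3,5-dibromo-2-hydroxyphenyl pattern would give a similar number on the core of compound 1, and whether a chloro or a methyl group at the new place in compound 4 would follow the second bromo. Also open, as far as these compounds go, is whether an amine or a carboxylic acid there would move the number in the same direction.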